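A few compounds are considered here, and "the series" means these few. Any claim that something is new, unique, unknown or untested is made for them only; others in the source may bear on it.

Of the compounds shown here, three sharing one core have been measured in a functional assay on KBVIN cells (Homo sapiens) for antiproliferative activity, read by sulforhodamine B assay, with a stated time of 3 days; a lower number here means that less compound is needed, a higher number that more compound is needed for the effect. Compound 1, `CCC1=C(O)c2c(oc(-c3ccccc3C(F)(F)F)cc2=O)C(CC)(CC)C1=O`, gives 43.1 uM. Compound 2, `CCC1=C(O)c2c(oc(-c3ccc(C)cc3C)cc2=O)C(CC)(CC)C1=O`, gives 8.52 uM. Compound 3, `CCC1=C(O)c2c(oc(-c3cc(Cl)c(OC)c(OC)c3)cc2=O)C(CC)(CC)C1=O`, gives 8.4 uM. Compound 2 thus stands second highest of the three numbers, with compound 3 within the scatter of it and compound 1 beyond the scatter at a higher number. Compound 4, `CCC1=C(O)c2c(oc(-c3cc(C)ccc3C)cc2=O)C(CC)(CC)C1=O`, has not yet been measured; it holds the same atoms as compound 2, joined differently: 2,5-dimethylphenyl in place of 2,4-dimethylphenyl on an aromatic carbon. Among the compounds with values here, no step between measured compounds shows what such a rearrangement does here. The expected step is a 1.2-fold higher number from compound 2 to compound 4 (0.07 log units; within the scatter), in no clear direction and not beyond the scatter. Compound 4 is therefore estimated at 10 uM, within 4 uM to 25 uM.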

Compound 4, concentration for half-maximal effect: 3.41 uM
The estimate for compound 4 lay 2.9-fold (0.47 log units) above the measured number; measured number below the stated range.
By their numbers in this assay, from the lowest: compound 4; then compounds 3 and 2 (each within the scatter of the next); then compound 1.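

Within this assay, replacing 2,4-dimethylphenyl with 2,5-dimethylphenyl on the shared core gives a clear change (a 2.5-fold lower number from compound 2 to compound 4 (0.40 log units; beyond the scatter)). Within the data shown here, the two compounds hold the same atoms, so the arrangement of the two methyl groups on this phenyl ring matters here, which the earlier compounds could not show. No measurement shown here explains the shift. On these data alone, it remains open whether the same rearrangement would give a similar gain with other groups, such as two ethyl chains, or with an amine or a carboxylic acid on this phenyl ring.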